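Pentyl to isopropyl on the five-membered ring

The source may report more compounds than this note shows. Statements on the series, on what has been measured and on what is new or still open speak of the compounds shown alone.

For the measured compounds named here, compound 1 `CCCCCc1onc(-c2ccccc2)c1C1C(C(=O)OCC)=C(C)N=C(C)/C1=C(/O)OCC` gives 79 nM in an assay on membranes from heart (Cavia porcellus) for binding affinity to Voltage-dependent L-type calcium channel subunit alpha-1C (Homo sapiens) (a higher number here means a weaker inhibitor, a lower number a stronger inhibitor), the highest of the three numbers measured so far. Compound 2 `CCOC(=O)C1=C(C)N=C(C)/C(=C(/O)OCC)C1c1c(C)noc1CC` gives 52 nM in this assay, within the scatter of compound 1; compound 3 `CCOC(=O)C1=C(C)N=C(C)/C(=C(/O)OCC)C1c1c(C)noc1C` gives 27.1 nM, beyond the scatter from compound 1. Going by the values given here, the only one-place step among measured compounds, a 1.9-fold lower number from compound 2 to compound 3 (0.28 log units; within the scatter), is a chain shortening on a saturated chain carbon bound to an aromatic carbon of the five-membered ring and stays within the scatter.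

Compound 4 `CCOC(=O)C1=C(C)N=C(C)/C(=C(/O)OCC)C1c1c(-c2ccccc2)noc1C(C)C` differs from compound 1 by isopropyl in place of pentyl on an aromatic carbon. The step from compound 2 to compound 3 is the closest analogy, a shorter chain on the same five-membered aromatic ring with 1 nitrogen and 1 oxygen, and it moved the number only within the scatter. No step beyond the scatter is therefore expected for compound 4 in this assay, with at most a slight lowering, a 1.3-fold lower number from compound 1 to compound 4 (0.12 log units; within the scatter). The estimate for compound 4 is 60 nM, expected to fall between 25 nM and 150 nM.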

Compound 4, inhibition constant: 417 nM
Compound 4: the middle estimate sits 7.0-fold (0.84 log units) below what was measured; the whole stated range lies below it.
By their numbers in this assay, from the lowest: compounds 3, 2 and 1 (each within the scatter of the next, the first and the last beyond it); then compound 4.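

In this assay, for the compounds shown here, this place on the ring responds to the chain: isopropyl in place of pentyl gives a 5.3-fold higher number from compound 1 to compound 4 (0.72 log units; beyond the scatter) and is the first one-place step to lie beyond the scatter. The other chain shortening in the series shows a 1.9-fold lower number from compound 2 to compound 3 (0.28 log units; within the scatter) and stays within the scatter, on a ring bearing methyl rather than phenyl, so shortening a chain on this ring does not have one outcome across the two pairs.

Pentyl and isopropyl differ in both length and branching, so an unbranched propyl chain here would separate the two, and isopropyl paired with methyl in place of the phenyl group would show whether the larger step depends on that phenyl group. No available evidence bears on the reason for the step.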